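Swapping a diol-bearing group for an epoxide-bearing one

The source may report more compounds than this note shows. Statements on the series, on what has been measured and on what is new or still open speak of the compounds shown alone.

Measured so far in a functional assay on Ramos cells (Homo sapiens) for antiproliferative activity; on this read-out lower numbers stand for stronger inhibition and higher numbers for weaker inhibition
compound 1 `Nc1ncnc2c1c(-c1ccc(Oc3ccccc3)cc1)cn2C[C@H]1CCCN1C(CO)CO` gives 15300 nM
compound 2 `CC(C)(C)c1ccc(Oc2ccc(-c3cn([C@H]4CCN(C[C@@H]5CO5)C4)c4ncnc(N)c34)cc2)cc1` gives 11200 nM
compound 3 `CC(C)(C)c1ccc(C(=O)Nc2ccc(-c3cn([C@H]4CCN(C[C@@H]5CO5)C4)c4ncnc(N)c34)cc2)cc1` gives 2970 nM

In this assay compound 1 has the highest number of the three, but compound 2 lies within the scatter of it. Only compound 3 lies lower by more than the scatter.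

Compound 4 `Nc1ncnc2c1c(-c1ccc(Oc3ccccc3)cc1)cn2C[C@H]1CCCN1C[C@@H]1CO1` has not yet been measured. The change from compound 1 reads (oxiran-2-yl)methyl in place of 2-hydroxy-1-(hydroxymethyl)ethyl on an amine nitrogen in a ring and places (oxiran-2-yl)methyl in place of 2-hydroxy-1-(hydroxymethyl)ethyl on an amine nitrogen in a ring.

Among the compounds with values here, no measured pair shows this change alone. Compound 2 at 11200 nM and compound 3 at 2970 nM both carry (oxiran-2-yl)methyl, yet both also differ from compound 1 elsewhere. Their values therefore give only loose guidance, one within the scatter of compound 1 and one beyond it. A small expected step towards stronger inhibition, within the scatter, seems the fairest reading (a 1.9-fold lower number from compound 1 to compound 4 (0.28 log units; within the scatter)). For compound 4 the estimated value in this assay is 8000 nM (expected range 2500 nM to 20000 nM).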

Compound 4, half-maximal inhibitory concentration: 8520 nM
Beside the measured number, compound 4's estimate is 1.1-fold (0.03 log units) below it, within the range that was stated.
By their numbers in this assay, from the lowest: compound 3; then compounds 4, 2 and 1 (each within the scatter of the next).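

In this assay, within the data shown here, this pair gives the first direct reading of (oxiran-2-yl)methyl in place of 2-hydroxy-1-(hydroxymethyl)ethyl on an amine nitrogen in a ring, with the rest of the structure held constant (a 1.8-fold lower number from compound 1 to compound 4 (0.25 log units; within the scatter)). As this step lies within the scatter, the read-out does not separate the two compounds, although the group that leaves has no ring and 2 hydrogen-bond donors, while the group that enters has one three-membered non-aromatic ring, 0 hydrogen-bond donors and 1 defined stereocentre. Nothing available here bears on why compound 1 and compound 4 read alike.

Compound 2 and compound 3 differ from compound 4 in more than one place, so they cannot show whether this result holds with other groups elsewhere on the molecule. As far as these compounds go, it also remains open whether a 2-aminoethyl group, a carboxylic acid or a longer chain on the same nitrogen, or the opposite configuration at the defined stereocentre of the (oxiran-2-yl)methyl group, would give a step beyond the scatter.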